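The compounds below may be only part of what the source reports. "The series", "measured", "known", "first", "only" and "open" are said of these compounds alone.

Of the compounds shown here, two sharing one core have so far been tested in a functional assay on B16 cells (Mus musculus) for antiproliferative activity, with a stated time of 72 h; a higher number here means a weaker inhibitor, a lower number a stronger inhibitor. Compound 1 `C#CCSc1cnc2ccccc2c1[Se]CC#CCCl` gives 7.1 ug/mL in this assay, and compound 2 `CSc1cnc2ccccc2c1[Se]CC#CCO` gives 4.2 ug/mL. Compound 2 carries the smaller of the two numbers, but its gap to compound 1 lies within the scatter of repeated measurements, so the two cannot be ranked against each other. Compound 3 `CSc1cnc2ccccc2c1[Se]CC#CCCl` has not yet been measured. It differs from compound 2 in a single place: chloro in place of hydroxy on a saturated chain carbon bound to a triple-bonded carbon. For the measured compounds named here, no measured pair shows this change by itself, so there is no step to lean on; the nearest hint is compound 1, which already carries the chloro end elsewhere on the molecule and gives 7.1 ug/mL. Compound 3 is therefore expected to land close to compound 2, with the step of a 1.2-fold higher number from compound 2 to compound 3 (0.08 log units; within the scatter) estimated to stay within the scatter or barely beyond it. The estimate for compound 3 in this assay is 5 ug/mL, with a range from 2.5 ug/mL to 12 ug/mL.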

Compound 3, concentration for 50% inhibition: 3.5 ug/mL
Compound 3: middle estimate off by 1.4-fold (0.15 log units), on the high side; the measured number falls inside the stated range.
By their numbers in this assay, from the lowest: compounds 3, 2 and 1 (each within the scatter of the next, the first and the last beyond it).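

In this assay, chloro in place of hydroxy on a saturated chain carbon bound to a triple-bonded carbon gives a 1.2-fold lower number from compound 2 to compound 3 (0.08 log units; within the scatter) and so leaves the number within the scatter, although hydroxy counts a hydrogen-bond donor and acceptor and chloro counts neither. Hydrogen in place of ethynyl on a saturated chain carbon bound to a sulfur gives a 2.0-fold lower number from compound 1 to compound 3 (0.31 log units; beyond the scatter) and is the only step here that clears the scatter, and only modestly. Nothing measured here explains either step.

Going by these compounds, whether an amine or a carboxylic acid at the end of this chain would also stay close to compound 3 remains open. So does the effect of a longer chain in place of the 4-chlorobut-2-yn-1-yl group.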